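This account rests on a few compounds, and the source may have more. Where it says the series, first, only, none or still open, it means among the compounds named here.

Measured compounds:
compound 1 `CS(=O)(=O)c1ccc(Cl)c(C#Cc2cc(Cl)ccc2OCC(=O)O)c1`: in an assay on CHO cells for displacement of a labelled ligand from prostaglandin D2 receptor 2 (Homo sapiens), read by scintillation counting (on this read-out higher numbers stand for weaker inhibition and lower numbers for stronger inhibition), compound 1 gives 3.5 nM
compound 2 `Cc1ccc(S(=O)(=O)N(C)CC(C)C)cc1C#Cc1cc(Cl)ccc1OCC(=O)O`: in this assay compound 2 gives 4.2 nM

Among these two numbers compound 2 holds the higher one, but its nearest neighbour, compound 1, sits within the scatter of it, so the two results are not distinguishable. Compound 3 `Cc1ccc(S(C)(=O)=O)cc1C#Cc1cc(Cl)ccc1OCC(=O)O` is the not yet measured compound. It arises from compound 2 by the change (methyl in place of isobutyl(methyl)amino on a sulfonyl sulfur), which brings the same methylsulfonyl group that compound 1 carries. Going by the values given here, no step between two measured compounds covers this change, and compound 1 and compound 2 differ in more than this one place, so their pair gives only the two values shown. Given that compound 1 with the methylsulfonyl group gives 3.5 nM, compound 3 is expected to stay close to compound 2, with a step of a 1.1-fold lower number from compound 2 to compound 3 (0.02 log units; within the scatter) that lies within the scatter. The estimate for compound 3 is 4 nM, between 1.5 nM and 12 nM.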

Compound 3, inhibition constant: 5 nM
Estimate against measurement, compound 3: 1.3-fold (0.10 log units) below; the range from low to high includes it.
By their numbers in this assay, from the lowest: compounds 1, 2 and 3 (each within the scatter of the next).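

In this assay, methyl in place of isobutyl(methyl)amino on a sulfonyl sulfur gives a 1.2-fold higher number from compound 2 to compound 3 (0.08 log units; within the scatter), so at this position the small methylsulfonyl group and the much larger isobutyl(methyl)sulfamoyl group cannot be told apart. Methyl in place of chloro on an aromatic carbon gives a 1.4-fold higher number from compound 1 to compound 3 (0.15 log units; within the scatter), so these two groups cannot be told apart at their position either, and neither change moves the result beyond the scatter. Nothing available here explains why these results lie so close together.

The compounds shown leave open whether an unsubstituted amino group or a piperidine ring on the sulfonyl sulfur would also fit this pattern. They also leave open whether a methoxy group or a bromo on that aromatic carbon would give a result distinct from methyl and chloro.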